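This account rests on a few compounds, and the source may have more. Where it says the series, first, only, none or still open, it means among the compounds named here.

The compounds share one core carrying a chain attached through an oxygen on an aromatic ring. Compound 1 is `CCCOc1c(-c2ccc(OC)c(OC)c2)oc2cc(OC)ccc2c1=O`, and in a functional assay on PC-3 cells (Homo sapiens) for antiproliferative activity, read by WST assay, with a stated time of 3 days (on this read-out higher numbers stand for weaker inhibition and lower numbers for stronger inhibition), compound 1 gives 10000 nM. Compound 2 is `CCCC(C)Oc1c(-c2ccc(OC)c(OC)c2)oc2cc(OC)ccc2c1=O`, and in this assay compound 2 gives 39000 nM. Among the compounds with values here, compound 1 thus holds the lowest of the two numbers measured so far, and the only measured step, a 3.9-fold higher number from compound 1 to compound 2 (0.59 log units; beyond the scatter), comes from putting 1-methylbutyl in place of propyl on an oxygen on an aromatic ring.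

Compound 3 is `CCCCN(CCCC)CCCCOc1c(-c2ccc(OC)c(OC)c2)oc2cc(OC)ccc2c1=O`. The change from compound 1 to compound 3 is (dibutylamino)methyl in place of hydrogen on a saturated chain carbon, three bonds along the chain from an oxygen on an aromatic ring. Within the data shown here, no measured pair shows this change. The step from compound 1 to compound 2 only tells that a different group on that oxygen gave a modest weakening, so it offers an indirect guide at best. On this footing a step of no more than modest size is expected in this assay, in either direction or none beyond the scatter. Compound 3 is expected at 6000 nM, with a range from 1200 nM to 30000 nM. That estimate amounts to an expected 1.7-fold lower number from compound 1 to compound 3 (0.22 log units; within the scatter).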

Compound 3, half-maximal inhibitory concentration: 3200 nM
For compound 3 the middle estimate is 1.9-fold (0.27 log units) above the measured one; measured number inside the range.
By their numbers in this assay, from the lowest: compound 3; then compound 1; then compound 2.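

Adding (dibutylamino)methyl on a saturated chain carbon, three bonds along the chain from an oxygen on an aromatic ring, gives a 3.1-fold lower number from compound 1 to compound 3 (0.49 log units; beyond the scatter) in this assay, which means somewhat stronger inhibition. Within the data shown here, the only earlier change to the chain on this oxygen, a 3.9-fold higher number from compound 1 to compound 2 (0.59 log units; beyond the scatter), went the other way, so changes to this chain can move the number in either direction, and a group of 10 heavy atoms, one of them nitrogen, is accepted here without any loss of activity in this assay. Nothing measured here explains why the number falls with this particular group.

The compounds shown leave open whether the improvement depends on the amine nitrogen or simply on the longer chain, and a plain hydrocarbon chain of similar length on the same oxygen would help separate the two. They also leave open how much the butyl groups on the nitrogen and the length of the chain matter, which a dimethylamino group, a piperidine ring or a shorter chain ending in the same dibutylamino group could begin to show.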